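The compounds below may be only part of what the source reports. "The series", "measured", "known", "first", "only" and "open" are said of these compounds alone.

Working notes on the series. The shared core of compound 1 `CCNC(=O)c1cc(Oc2cccc(NC(=S)Nc3ccc(F)c(F)c3)c2)ccn1` carries an amide that is varied across three compounds and a thiourea bearing a 3,4-difluorophenyl group. In a functional assay on PC-3 cells (Homo sapiens) for cytotoxicity, read by MTT assay, with a stated time of 48 h (a higher number here means a weaker inhibitor, a lower number a stronger inhibitor), compound 1 gives 26300 nM. Compound 2 `O=C(NC1CCCCC1)c1cc(Oc2cccc(NC(=S)Nc3ccc(F)c(F)c3)c2)ccn1` gives 8100 nM, and compound 3 `O=C(c1cc(Oc2cccc(NC(=S)Nc3ccc(F)c(F)c3)c2)ccn1)N1CCCC1` gives 45600 nM. The steps at the amide are a 3.2-fold lower number from compound 1 to compound 2 (0.51 log units; beyond the scatter) and a 5.6-fold higher number from compound 2 to compound 3 (0.75 log units; beyond the scatter), while a 1.7-fold higher number from compound 1 to compound 3 (0.24 log units; within the scatter). Compound 3 thus stands with the highest number of the three; its gap to compound 1 lies within the scatter and only its gap to compound 2 lies beyond it, so compound 3 is not the weakest outright.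

Compound 4 `O=C(c1cc(Oc2cccc(NC(=S)Nc3ccc(Cl)c(C(F)(F)F)c3)c2)ccn1)N1CCCC1` keeps the pyrrolidin-1-yl amide of compound 3 and changes the thiourea side: 4-chloro-3-(trifluoromethyl)phenyl in place of 3,4-difluorophenyl on an amide-type nitrogen. None of the measured steps touches this position; all three concern the amide alone, so no measured step bears directly on the change, and neither its direction nor its size can be read from the compounds shown. The expected step is accordingly small, a 1.3-fold lower number from compound 3 to compound 4 (0.11 log units; within the scatter), with nothing expected beyond the scatter. For the measured compounds named here, for compound 4 the estimate in this assay is 35000 nM, with a range of 9000 nM to 130000 nM; the range is wide, as no measured step informs it.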

Compound 4, half-maximal inhibitory concentration: 12100 nM
Compound 4: the middle estimate sits 2.9-fold (0.46 log units) above what was measured; the range from low to high includes it.
By their numbers in this assay, from the lowest: compounds 2 and 4 (each within the scatter of the next); then compounds 1 and 3 (each within the scatter of the next).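

The thiourea side proves to be a position that can move the number: in this assay, 4-chloro-3-(trifluoromethyl)phenyl in place of 3,4-difluorophenyl on an amide-type nitrogen gives a 3.8-fold lower number from compound 3 to compound 4 (0.58 log units; beyond the scatter), a modest step beyond the scatter. For the compounds shown here, this is the first measured change away from the amide, and it shows that, with the pyrrolidin-1-yl amide held fixed, the aryl group on the thiourea also bears on the reading. The two groups match in carrying no hydrogen-bond donors, no hydrogen-bond acceptors and no net charge, and differ in heavy atoms, with more entering than leaving, but no measurement on hand accounts for the step.

This single pair leaves open whether the same aryl change gives a step of similar size on the ethyl amide of compound 1 or the cyclohexyl amide of compound 2. Also open, from the compounds shown here alone, are the separate contributions of the chlorine and the trifluoromethyl, and how a thiourea aryl group bearing a methoxy group or a nitrile would read in this assay.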